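The compounds below may be only part of what the source reports. "The series", "measured", "known", "first", "only" and "open" are said of these compounds alone.

Measured so far in a functional assay on MGC-803 cells (Homo sapiens) for inhibition, read by sulforhodamine B assay; a lower number here means a stronger inhibitor, a higher number a weaker inhibitor:
Compound 1 `Cc1ccc(NC2=CC(=O)c3nc4n(c3C2=O)[C@H]2OC[C@@H](O)[C@H]2OC4)cc1C` gives 860 nM.
Compound 2 `CCCc1ccc(NC2=CC(=O)c3c(nc4n3[C@H]3OC[C@@H](O)[C@H]3OC4)C2=O)cc1` gives 1920 nM.
Compound 3 `CCc1ccc(NC2=CC(=O)c3nc4n(c3C2=O)[C@H]2OC[C@@H](O)[C@H]2OC4)cc1` gives 1290 nM.

Compound 2 stands at the highest number of the three. Compound 3 sits nearest, and the two values lie within the scatter of each other, so no order can be read between them. Compound 1 sits furthest, at a number beyond the scatter below that of compound 2, so compound 2 is the weaker inhibitor of that pair.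

Compound 4 `Cc1ccc(NC2=CC(=O)c3c(nc4n3[C@H]3OC[C@@H](O)[C@H]3OC4)C2=O)cc1` is not yet measured. It differs from compound 2 in one place: hydrogen in place of ethyl on a saturated chain carbon bound to an aromatic carbon. Going by the values given here, the only measured step that changes a single place is the one from compound 1 to compound 3, a 1.5-fold higher number from compound 1 to compound 3 (0.18 log units; within the scatter), which swaps one substitution pattern on the aromatic ring for another. Compound 2 and compound 3 differ in the length of the chain on that ring, and their values stand within the scatter of each other. Shortening the chain further gives no reason to expect a step beyond the scatter; the step expected in this assay is a 1.5-fold lower number from compound 2 to compound 4 (0.17 log units; within the scatter). Compound 4 is expected at 1300 nM, with a range from 650 nM to 2600 nM.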

Compound 4, half-maximal inhibitory concentration: 1550 nM
Compound 4: the middle estimate sits 1.2-fold (0.08 log units) below what was measured; the measured number falls inside the stated range.
By their numbers in this assay, from the lowest: compounds 1, 3, 4 and 2 (each within the scatter of the next, the first and the last beyond it).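

Cutting 4-propylphenyl back to 4-methylphenyl gives the first step measured directly at this position, and in this assay it reads a 1.2-fold lower number from compound 2 to compound 4 (0.09 log units; within the scatter) and so lies within the scatter. Replacing ethyl with hydrogen on a saturated chain carbon bound to an aromatic carbon therefore makes no readable difference between these two compounds, and the number does not depend on this part of the chain for this pair. Nothing available explains this result.

As far as these compounds go, whether a longer chain such as hexyl, or an amine or a carboxylic acid at this place, would move the number beyond the scatter remains open. Also open, from the compounds shown here alone, is how a plain phenyl ring, with hydrogen in place of the methyl, would compare with compound 4.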